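From diethylamino to isopropoxy on compound 3

The source may hold more compounds than are shown below. What is called first, only, known or untested is meant among the compounds shown, and "the series" means these compounds.

Values in a functional assay on HCT-116 cells (Homo sapiens) for antiproliferative activity, with a stated time of 48 h (on this read-out lower numbers stand for stronger inhibition and higher numbers for weaker inhibition), so far:
Compound 1 (`CCN(CC)c1ccc(-c2ccc(C#N)cc2)nn1`) gives > 25000 nM as a limit, not a number
Compound 2 (`CCN(CC)c1ccc(-c2ccc(C(=O)O)cc2)nn1`) gives > 25000 nM as a limit, not a number
Compound 3 (`CCOC(=O)c1ccc(-c2ccc(N(CC)CC)nn2)cc1`) gives 500 nM as a measured number

Compound 3 is the only one of the three with a true number. Compound 1 and compound 2 stop at a limit (the limit of > 25000 nM in this assay, at which 2 of the 3 values shown sit) and show nothing finer. The measured steps that matter are an at least 50-fold lower number from compound 1 to compound 3 (1.69 log units; beyond the scatter) and an at least 50-fold lower number from compound 2 to compound 3 (1.69 log units; beyond the scatter) and both are large, yet both concern the ethoxycarbonyl group.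

Compound 4 (`CCOC(=O)c1ccc(-c2ccc(OC(C)C)nn2)cc1`) keeps that group and carries isopropoxy in place of diethylamino (isopropoxy in place of diethylamino on an aromatic carbon) on an aromatic carbon. Among the compounds with values here, no measured step touches this place, so those large steps show only that one change can move the number a long way in this small set, not which way this change will go. A moderate move towards weaker inhibition is expected, read as a 2.4-fold higher number from compound 3 to compound 4 (0.38 log units; beyond the scatter) with wide doubt around it. The estimate for compound 4 is 1200 nM (range 200 nM to 8000 nM) and it is an expectation only.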

Compound 4, half-maximal inhibitory concentration: > 25000 nM
Compound 4: only a limit was reported; the forecaster's own chance of this, stated with the estimate: 15%; middle value at least 20-fold (1.31 log units) from the limit.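

In this assay, putting isopropoxy in place of diethylamino on the aromatic carbon next to the ring nitrogen, while keeping the ethoxycarbonyl group, gives an at least 50-fold higher number from compound 3 to compound 4 (1.69 log units; beyond the scatter). The ethoxycarbonyl group is therefore not enough on its own: this second position also decides whether a true number can be read, and only compound 3 combines ethoxycarbonyl with diethylamino. Compound 4 stops at a limit, not a number, and joins the other compounds that do so: the limit of > 25000 nM in this assay, at which 3 of the 4 values shown sit.

With only diethylamino and isopropoxy seen at this position alongside ethoxycarbonyl, the data do not tell whether the nitrogen of the amine or its two ethyl chains matter more. Another amine such as dimethylamino or pyrrolidine, or an ether such as ethoxy, could help separate these possibilities.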